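The compounds below may be only part of what the source reports. "The series", "measured", "known", "first", "only" and "open" are said of these compounds alone.

Compound 1 `CC1=NN(c2ccccc2)C(=O)[C@@]12C(=O)C=CC[C@H]2c1cccc(C)c1` and compound 2 `CC1=NN(c2ccccc2)C(=O)[C@@]12C(=O)C=CC[C@@H]2c1cccc(C)c1` both carry a 3-methylphenyl group on the same core. Within the data shown here, in a functional assay on HCT-116 cells (Homo sapiens) for inhibition, read by MTT assay, with a stated time of 72 h (a higher number here means a weaker inhibitor, a lower number a stronger inhibitor), compound 1 gives 5820 nM and compound 2 gives 3800 nM, so compound 2 stands level with the only other measured compound. Among the measured compounds shown here, the one measured step, a 1.5-fold lower number from compound 1 to compound 2 (0.19 log units; within the scatter), concerns (the fact that compounds 1 and 2 differ only in the configuration as drawn).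

Compound 3 `CC1=NN(c2ccccc2)C(=O)[C@@]12C(=O)C=CC[C@@H]2c1ccccc1` keeps the configuration of compound 2 and changes the aromatic ring: hydrogen in place of methyl on an aromatic carbon. This puts hydrogen in place of methyl on an aromatic carbon, turning 3-methylphenyl to phenyl. For the measured compounds named here, no measured step alters this methyl, so the data give no direction for removing it, and the small size of the one step offers only a weak guide. No shift beyond the scatter is expected in this assay. The estimated step is a 1.1-fold higher number from compound 2 to compound 3 (0.04 log units; within the scatter). For compound 3 the estimated value is 4200 nM, with a range of 1900 nM to 9500 nM.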

Compound 3, half-maximal inhibitory concentration: 6070 nM
Compound 3: the middle estimate sits 1.4-fold (0.16 log units) below what was measured; low and high end bracket the measured number.
By their numbers in this assay, from the lowest: compounds 2, 1 and 3 (each within the scatter of the next).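

Among these compounds, putting hydrogen in place of methyl on this aromatic carbon, turning 3-methylphenyl to phenyl, gives in this assay a 1.6-fold higher number from compound 2 to compound 3 (0.20 log units; within the scatter) and is the first measured step on the aromatic ring. With the configuration of compound 2 held fixed, this methyl therefore shows no effect that can be told apart from ordinary repeat variation in this assay. Nothing in the information available accounts for this result.

The compounds shown leave open whether a methoxy group, an amine or a carboxylic acid on this same aromatic carbon would give a step beyond the scatter. They also leave open whether the same swap of methyl for hydrogen in the configuration of compound 1 would give a similar step.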